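The source may report more compounds than this note shows. Statements on the series, on what has been measured and on what is new or still open speak of the compounds shown alone.

In a functional assay on PC-3 cells (Homo sapiens) for cytotoxicity, read by sulforhodamine B assay, with a stated time of 48 h (a lower number here means that less compound is tolerated, a higher number that more compound is tolerated), compound 3 `ClCc1cccc(Cn2cnc3c(Cl)nc(Cl)nc32)c1` gives 55000 nM, while compound 1 `ClCc1cccc(Cn2cnc3c(Cl)ncnc32)c1` gives 67600 nM. The change hydrogen in place of chloro on an aromatic carbon thus made a step of a 1.2-fold higher number from compound 3 to compound 1 (0.09 log units; within the scatter). Compound 2 `ClCc1ccc(Cn2cnc3nc(Cl)nc(Cl)c32)cc1` gives 75900 nM in this assay; how its core differs from the core of compound 3 is not broken down here. Compound 4 `ClCc1ccc(Cn2cnc3ncnc(Cl)c32)cc1` arises from compound 2 through (hydrogen in place of chloro on an aromatic carbon), the same change that turns compound 3 into compound 1. Because the earlier step of a 1.2-fold higher number from compound 3 to compound 1 (0.09 log units; within the scatter) lay within the scatter, the new step is expected to be of similar small size, and the estimate means a 1.2-fold higher number from compound 2 to compound 4 (0.07 log units; within the scatter). Compound 4 is therefore expected to give 90000 nM in this assay, with an estimated range from 45000 nM to 180000 nM.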

Compound 4, concentration lethal to 50% of the cells: 5370 nM
For compound 4 the middle estimate is 17-fold (1.22 log units) above the measured one, and the stated range ends above it.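

In this assay, hydrogen in place of chloro on an aromatic carbon gave a 14-fold lower number from compound 2 to compound 4 (1.15 log units; beyond the scatter). The change therefore did not carry over from one core to the other with the same size, and the step seen on the core of compound 3 was no guide to the step on the core of compound 2: the same change on two cores in this assay, a 1.2-fold higher number (0.09 log units; within the scatter) from compound 3 to compound 1 and a 14-fold lower number (1.15 log units; beyond the scatter) from compound 2 to compound 4, 17-fold (1.24 log units) apart, beyond the scatter of two such steps These two pairs do not show why the cores part, nor which of the two steps a third core would follow.

From the compounds shown here alone, it remains open whether an amine or a methoxy group on that same carbon, between two ring nitrogen atoms, would give a number near compound 2 or near compound 4. Going by these compounds, it also remains open whether the remaining chloro group contributes to the step.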